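The compounds below may be only part of what the source reports. "The series", "measured", "known", "first", "only" and "open" are said of these compounds alone.

Working notes on the hydrazone series

Three compounds have been run in a functional assay on A549 cells (Homo sapiens) for inhibition, read by MTT assay, with a stated time of 48 h; a lower number here means a stronger inhibitor, a higher number a weaker inhibitor. Compound 1 `COc1cc(/C=N/Nc2nc(-c3ccc(C(F)(F)F)cc3)cs2)c(Br)c(Br)c1OC` gives 17600 nM in this assay. Compound 2 `COc1cc(/C=N/Nc2nc(-c3cc(C(F)(F)F)cc(C(F)(F)F)c3)cs2)cc(Br)c1OC` gives 94200 nM in this assay, and compound 3 `COc1ccccc1-c1csc(N/N=C/c2ccc(F)c(F)c2)n1` gives 61300 nM in this assay. Among the three numbers compound 1 stands lowest; the gaps to compound 3 and to compound 2 both lie beyond the usual scatter, with compound 2 furthest away. For the measured compounds named here, none of the three pairs differs in only one place, so no single-point step between measured compounds is available, and the size of any one substituent change is not yet known.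

Compound 4 `COc1cc(/C=N/Nc2nc(-c3ccc(Br)cc3)cs2)c(Br)c(Br)c1OC` is next for this assay. It departs from compound 1 by one change: bromo in place of trifluoromethyl on an aromatic carbon, the 4-(trifluoromethyl)phenyl becoming a 4-bromophenyl. Going by the values given here, with no matching step among the measured compounds, the expectation rests on compound 1 alone and its value 17600 nM. The step of a 1.1-fold higher number from compound 1 to compound 4 (0.06 log units; within the scatter) is expected to stay within the scatter, with no clear direction. Compound 4 is therefore estimated at 20000 nM in this assay, with a range from 7000 nM to 55000 nM.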

Compound 4, half-maximal inhibitory concentration: 46100 nM
Compound 4: middle estimate off by 2.3-fold (0.36 log units), on the low side; the range from low to high includes it.
By their numbers in this assay, from the lowest: compound 1; then compounds 4, 3 and 2 (each within the scatter of the next, the first and the last beyond it).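

The series now has its first single-point step: in this assay, bromo in place of trifluoromethyl on this aromatic carbon, para to a large group, gives a 2.6-fold higher number from compound 1 to compound 4 (0.42 log units; beyond the scatter) and so moves the number towards a weaker inhibitor. With the rest of compound 1 held fixed, this position is therefore not indifferent to the group it carries, although the step is modest and rests on a single pair, with trifluoromethyl giving the lower number of the two on this core. The change replaces four heavy atoms with one and involves no ring, no hydrogen-bond donor or acceptor and no net charge, but no measurement at hand bears on why the number moves.

For the compounds shown here, what an amine, a carboxylic acid or a longer chain would give on this same carbon remains open, so the two groups compared here offer only a first reading of the position. Also open, on these data alone, is whether bromo in place of trifluoromethyl would give a step of similar size and the same direction on the different core substitution seen in compound 2 or compound 3.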